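Bromo in place of methyl: notes on the series

The compounds below may be only part of what the source reports. "The series", "measured", "known", "first", "only" and "open" are said of these compounds alone.

Measured in a functional assay on HCC 2998 cells (Homo sapiens) for antiproliferative activity; a lower number here means a stronger inhibitor of growth, a higher number a weaker inhibitor of growth
- Compound 1 `Oc1ccc(-c2nc3ccccc3s2)cc1O` gives 6990 nM
- Compound 2 `COc1ccc(-c2nc3cc(F)ccc3s2)cc1C` gives 540 nM

Of these two, compound 2 has the lower number, and its gap to compound 1 lies beyond the scatter. Compound 3 `COc1ccc(-c2nc3cc(F)ccc3s2)cc1Br` carries bromo in place of methyl on an aromatic carbon, ortho to a methoxy group bromo in place of methyl on an aromatic carbon in comparison with compound 2. Among the measured compounds shown here, no measured pair shows this exchange, so the expectation rests on the structural change alone: no step beyond the scatter in this assay. The estimated 1.4-fold lower number from compound 2 to compound 3 (0.13 log units; within the scatter) is therefore small. Compound 3 is expected at 400 nM with an estimated range of 60 nM to 2000 nM in this measurement.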

Compound 3, concentration for 50% growth inhibition: 3450 nM
The estimate for compound 3 lay 8.6-fold (0.94 log units) below the measured number; the measured number lies above the stated range.
By their numbers in this assay, from the lowest: compound 2; then compound 3; then compound 1.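

In this assay, bromo in place of methyl on this aromatic carbon, ortho to a methoxy group, is not a neutral exchange: the change gives a 6.4-fold higher number from compound 2 to compound 3 (0.81 log units; beyond the scatter). The number at this position therefore depends on the group it carries, even though both groups count one heavy atom, and of the two, methyl gives the lower number. Nothing at hand explains the difference.

On these data alone, whether chloro, ethyl or an amine on this carbon would stand nearer to methyl or to bromo remains open. Also open, as far as these compounds go, is whether the same step would appear on a core without the fluoro group.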